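Difluoromethyl in place of cyano: working notes

A few compounds are considered here, and "the series" means these few. Any claim that something is new, unique, unknown or untested is made for them only; others in the source may bear on it.

Three compounds sharing one core differ at a single aromatic carbon. Compound 1 (`Cc1c(/C=C/C(=O)O)cnc2ccc(O[C@@H](C)c3c(Cl)ccc(F)c3Cl)cc12`) gives 3 in a physicochemical assay for lipophilicity, using the shake flask method (a lower number here means a more polar compound, a higher number a more lipophilic compound), with methyl at that carbon. Compound 2 (`C[C@H](Oc1ccc2ncc(/C=C/C(=O)O)cc2c1)c1c(Cl)ccc(F)c1Cl`) gives 2.5 with hydrogen there, and compound 3 (`C[C@H](Oc1ccc2ncc(/C=C/C(=O)O)c(C#N)c2c1)c1c(Cl)ccc(F)c1Cl`) gives 2.3 with cyano there. Compound 3 stands within the scatter of compound 2 and clearly apart from compound 1.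

The two steps starting from methyl are a number 0.50 log units lower from compound 1 to compound 2 (beyond the scatter) and a number 0.70 log units lower from compound 1 to compound 3 (beyond the scatter) (both modest), while a number 0.20 log units lower from compound 2 to compound 3 (within the scatter) does not exceed the scatter. For the measured compounds named here, at the same carbon, compound 4 (`C[C@H](Oc1ccc2ncc(/C=C/C(=O)O)c(C(F)F)c2c1)c1c(Cl)ccc(F)c1Cl`) carries difluoromethyl in place of cyano (difluoromethyl in place of cyano on an aromatic carbon) and has no measured counterpart. Going by the values given here, no measured compound holds difluoromethyl, so these steps give a scale and no direct precedent.

A modest step in this assay is expected, with the number going up. Among the compounds with values here, that direction rests on compound 1, whose methyl group gives 3 as the only alkyl example at this carbon. The estimated step is a number 0.40 log units higher from compound 3 to compound 4 (beyond the scatter) and remains tentative. Compound 4 is expected at 2.7 with an estimated range of 2.3 to 3.1 in this measurement.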

Compound 4, distribution coefficient: 3.1
Estimate against measurement, compound 4: 0.40 log units below, and the stated range covers the measured number.
By their numbers in this assay, from the lowest: compounds 3 and 2 (each within the scatter of the next); then compounds 1 and 4 (each within the scatter of the next).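

In this assay, difluoromethyl in place of cyano gives a number 0.80 log units higher from compound 3 to compound 4 (beyond the scatter), and difluoromethyl in place of hydrogen gives a number 0.60 log units higher from compound 2 to compound 4 (beyond the scatter), so this carbon holds a group that clears the scatter from compound 2, which cyano does not do. Against methyl the reading is a number 0.10 log units higher from compound 1 to compound 4 (within the scatter), which leaves compound 1 and compound 4 indistinguishable in this measurement and sorts the four compounds into two pairs at this carbon: cyano with hydrogen, and methyl with difluoromethyl. Nothing available on these compounds explains why difluoromethyl falls with methyl and not with cyano.

Still open, on these data alone, is where trifluoromethyl, an ethyl chain, a methoxy group or an amine at the same carbon would fall, and whether any of them would sit with either pair or apart from both. As far as these compounds go, it is also open whether the same swap of cyano for difluoromethyl would give a step of similar size at another carbon of the shared core, since all four compounds differ at this one place only.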